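A few compounds are considered here, and "the series" means these few. Any claim that something is new, unique, unknown or untested is made for them only; others in the source may bear on it.

Measured so far in a toxicity assay on HEK293 cells (Homo sapiens) for inhibition, read by resazurin assay, with a stated time of 24 h; a higher number here means that more compound is tolerated, a lower number that less compound is tolerated:
- compound 1 `Cn1c([N+](=O)[O-])cnc1C(=O)NCc1ccccn1`: > 100000 nM
- compound 2 `O=C(NCc1ccc(F)cc1)c1ncc([N+](=O)[O-])[nH]1`: > 100000 nM

Neither entry is an exact number. Compound 1 stands at > 100000 nM, which is a limit of the assay. Compound 2 gives > 100000 nM, which is also a limit. The whole record so far is therefore (the limit of > 100000 nM in this assay, at which 2 of the 2 values shown sit), and compound 1 cannot be ranked against compound 2.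

Compound 3 `O=C(NCc1ccccn1)c1ncc([N+](=O)[O-])[nH]1` has not yet been measured. It differs from compound 1 in a single place: hydrogen in place of methyl on an aromatic nitrogen. Put simply, hydrogen takes the place of methyl on an aromatic nitrogen.

For the measured compounds named here, no two measured compounds differ in just one place, so no measured step can serve as a guide. The expectation rests on the two limits alone, and in this assay no step beyond the usual scatter is expected in either direction. The expected step is a number no higher from compound 1 to compound 3 (the limit leaves the size open). The assay may well report only a limit again. For compound 3 the estimated value is 100000 nM, with an expected range of 50000 nM to 200000 nM.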

Compound 3, half-maximal cytotoxic concentration: > 100000 nM
Compound 3: no number, only a limit; the forecaster's own chance of this, stated with the estimate: 85%; the middle value sits exactly at the limit.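

In this assay, for the compounds shown here, compound 3, like compound 1, gives only a limit of the assay and not a number, so no step between the two can be read: the limit of > 100000 nM in this assay, at which 3 of the 3 values shown sit. The compounds shown leave open where each true cytotoxic concentration lies, and whether hydrogen in place of methyl on an aromatic nitrogen changes it at all.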